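This account rests on a few compounds, and the source may have more. Where it says the series, first, only, none or still open, it means among the compounds named here.

Measured so far:
Compound 1 `Cc1ncncc1-c1nc2cc(F)c(F)cc2n1C1CC1` gives 4160 nM in an ADME assay on cells for inhibition of cytochrome P450 11B1, mitochondrial (Homo sapiens), read by HPLC, with a stated time of 60 min; on this read-out higher numbers stand for weaker inhibition and lower numbers for stronger inhibition.
Compound 2 `CNc1ncncc1-c1nc2cc(F)c(F)cc2n1C1CC1` gives 390 nM in this assay.
Compound 3 `Fc1cc2nc(-c3cncnc3NCCC(F)(F)F)n(C3CC3)c2cc1F` gives 378 nM in this assay.

Compound 3 has the lowest number of the three, but its gap to compound 2 is within the scatter, so the two cannot be ranked against each other. Compound 4 `Fc1cc2nc(-c3cncnc3C(F)(F)F)n(C3CC3)c2cc1F` differs from compound 3 by trifluoromethyl in place of (3,3,3-trifluoropropyl)amino on an aromatic carbon. For the measured compounds named here, two measured steps bear on this change: an 11-fold lower number from compound 1 to compound 2 (1.03 log units; beyond the scatter) and an 11-fold lower number from compound 1 to compound 3 (1.04 log units; beyond the scatter), both large, while a 1.0-fold lower number from compound 2 to compound 3 (0.01 log units; within the scatter) shows no difference. Compound 4 keeps no amino group at that carbon, so its number is expected to move back toward that of compound 1 at 4160 nM. Compound 4 is therefore estimated at 2500 nM, within a range of 700 nM to 9000 nM, which would mean a 6.6-fold higher number from compound 3 to compound 4 (0.82 log units; beyond the scatter).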

Compound 4, half-maximal inhibitory concentration: 4770 nM
Beside the measured number, compound 4's estimate is 1.9-fold (0.28 log units) below it, and the stated range covers the measured number.
By their numbers in this assay, from the lowest: compounds 3 and 2 (each within the scatter of the next); then compounds 1 and 4 (each within the scatter of the next).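

In this assay, trifluoromethyl at this carbon gives a 13-fold higher number from compound 3 to compound 4 (1.10 log units; beyond the scatter) and a 12-fold higher number from compound 2 to compound 4 (1.09 log units; beyond the scatter), while a 1.1-fold higher number from compound 1 to compound 4 (0.06 log units; within the scatter) stays within the scatter. Compounds 2 and 3, with an amino nitrogen on this carbon, thus stand apart from compounds 1 and 4, where methyl or trifluoromethyl sits there, and fluorine on that single carbon makes no readable difference. No measurement shown here gives a cause for this.

Whether the nitrogen alone accounts for the gap stays open. A plain amino group, a dimethylamino group or a methoxy group at this carbon could help to settle that.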